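A few compounds are considered here, and "the series" means these few. Any claim that something is new, unique, unknown or untested is made for them only; others in the source may bear on it.

Working notes on the series. In an assay on HEK293 cells for activation of Kir3.1/Kir3.2 (Homo sapiens), read by thallium flux (on this read-out higher numbers stand for an effect only at larger amounts of compound and lower numbers for an effect already at smaller amounts), compound 1 `O=C(Cn1nnc(-c2ccccc2)n1)Nc1cc(C2CC2)nn1C1CCCCC1` gives 271 nM. In this assay, for the measured compounds named here, compound 2 `Cc1cc(NC(=O)Cn2nnc(-c3cc(Cl)cc(Cl)c3)n2)n(C2CCCCC2)n1` gives 980 nM, the higher of the two numbers so far; the gap to compound 1 lies beyond the scatter. Compound 3 `COc1ccc(-c2nnn(CC(=O)Nc3cc(C)nn3C3CCCCC3)n2)cc1` has not yet been measured. It differs from compound 2 as follows: 4-methoxyphenyl in place of 3,5-dichlorophenyl on an aromatic carbon. Going by the values given here, no measured pair shows this change, so the direction is open; a small step, not clearly beyond the scatter, is expected from compound 2, as a 1.2-fold higher number from compound 2 to compound 3 (0.09 log units; within the scatter). For compound 3 the estimate in this assay is 1200 nM, with a range from 400 nM to 3500 nM.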

Compound 3, half-maximal effective concentration: 175 nM
Estimate against measurement, compound 3: 6.9-fold (0.84 log units) above; measured number outside the range, below it.
By their numbers in this assay, from the lowest: compounds 3 and 1 (each within the scatter of the next); then compound 2.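

In this assay, this position on the five-membered aromatic ring with 4 nitrogen responds to the choice of aryl group, with 4-methoxyphenyl in place of 3,5-dichlorophenyl giving a 5.6-fold lower number from compound 2 to compound 3 (0.75 log units; beyond the scatter). The two groups match in heavy-atom count, while the entering group holds one hydrogen-bond acceptor and the leaving group none. No measurement at hand accounts for the step.

Still open, from the compounds shown here alone, is whether the methoxy group, its place on the phenyl ring or the loss of both chlorines carries the step. A 4-chlorophenyl or a 3-methoxyphenyl on the core of compound 2 would separate these.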